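Aryl ether substituent variations, compound 1 to compound 4

A few compounds are considered here, and "the series" means these few. Any claim that something is new, unique, unknown or untested is made for them only; others in the source may bear on it.

Measured in a functional assay on RAW264.7 cells (Mus musculus) for inhibition, read by Griess assay, with stated times of 1 h and 24 h; on this read-out lower numbers stand for stronger inhibition and higher numbers for weaker inhibition:
compound 1 `CCOc1ccc(C(O)C2OC(=O)c3c(OC)cc(OC)cc32)cc1`: > 10000 nM
compound 2 `COCCCCOc1ccc(C(O)C2OC(=O)c3c(OC)cc(OC)cc32)cc1`: 8210 nM
compound 3 `C=CCCOc1ccc(C(O)C2OC(=O)c3c(OC)cc(OC)cc32)cc1`: 1330 nM

Compound 1 stands only at a limit of this assay; its value is not a number, as the limit of > 10000 nM in this assay, at which 1 of the 3 values shown sits, records. Compound 4 `COc1cc(OC)c2c(c1)C(C(O)c1ccc(OCc3ccc(Br)cc3)cc1)OC2=O` differs from compound 1 by 4-bromophenyl in place of methyl on a saturated chain carbon bound to an oxygen on an aromatic ring. Going by the values given here, the steps that bear on this both lengthen the same chain: an at least 1.2-fold lower number from compound 1 to compound 2 (0.08 log units; that floor lies within the scatter) and an at least 7.5-fold lower number from compound 1 to compound 3 (0.87 log units; beyond the scatter), the gap between them given by a 6.2-fold lower number from compound 2 to compound 3 (0.79 log units; beyond the scatter). The vinyl extension lowered the number beyond the scatter, while the 2-methoxyethyl extension stayed within it, so chain size alone does not carry the effect, compound 2 standing against that reading. A 4-bromophenyl extension is nonetheless expected to lower the number beyond the scatter, and an at least 6.6-fold lower number from compound 1 to compound 4 (0.82 log units; beyond the scatter) is the estimated step. For compound 4 the expected value is 1500 nM, within 300 nM to 7000 nM.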

Compound 4, half-maximal inhibitory concentration: 6530 nM
Estimate against measurement, compound 4: 4.4-fold (0.64 log units) below; low and high end bracket the measured number.
By their numbers in this assay, from the lowest: compound 3; then compounds 4 and 2 (each within the scatter of the next). At a limit, above all of these: compound 1.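

At this position a ring-bearing extension does not reproduce the allyl result, giving a 4.9-fold higher number from compound 3 to compound 4 (0.69 log units; beyond the scatter). Instead, 4-bromophenyl sits level with the 3-methoxypropyl chain, with a 1.3-fold lower number from compound 2 to compound 4 (0.10 log units; within the scatter), so across compounds 2, 3 and 4 only compound 3 stands apart. The change from methyl gives an at least 1.5-fold lower number from compound 1 to compound 4 (0.18 log units; that floor lies within the scatter), which is only a floor, since compound 1 is a limit: the limit of > 10000 nM in this assay, at which 1 of the 4 values shown sits.

From the compounds shown here alone, whether the result of compound 3 belongs to the allyl group itself remains open. A plain butyl chain, a propargyl group or an unsubstituted phenyl at this place would bear on that.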